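Replacing the sulfonamide of compound 1 with a pyrazole

The compounds below may be only part of what the source reports. "The series", "measured", "known", "first", "only" and "open" are said of these compounds alone.

Compound 1 `CS(=O)(=O)Nc1cccc2c1CCC2c1ncc[nH]1` was tested in a functional assay on CHO cells for agonist activity at Alpha-1A adrenergic receptor (Homo sapiens), read by FLIPR and calcium flux (on this read-out higher numbers stand for an effect only at larger amounts of compound and lower numbers for an effect already at smaller amounts), and gives 70 nM. Among the two measured compounds it gives the highest number; its nearest neighbour is compound 2 `Cc1ccc2c(c1NS(C)(=O)=O)CCC2c1ncc[nH]1`, which gives 33 nM, the step being a 2.1-fold lower number from compound 1 to compound 2 (0.33 log units; beyond the scatter). Compound 3 `c1cc(-c2cn[nH]c2)c2c(c1)C(c1ncc[nH]1)CC2` differs from compound 1 in one place: 1H-pyrazol-4-yl in place of methanesulfonamido on an aromatic carbon. Going by the values given here, the single measured step, from compound 1 to compound 2, concerns a methyl added on an aromatic carbon and therefore does not test an exchange of the methanesulfonamido group; no measured step bears directly on this change. Since the substituent with one hydrogen-bond donor and two hydrogen-bond acceptors gives way to an aromatic ring with one donor and one acceptor, a step of uncertain direction is expected, most likely a moderate rise in the number, a 2.1-fold higher number from compound 1 to compound 3 (0.33 log units; beyond the scatter). Compound 3 is therefore estimated at 150 nM, in a range from 30 nM to 800 nM.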

Compound 3, half-maximal effective concentration: 14 nM
Compound 3: middle estimate off by 11-fold (1.03 log units), on the high side; the measured number lies below the stated range.
By their numbers in this assay, from the lowest: compound 3; then compound 2; then compound 1.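

In this assay, the exchange of methanesulfonamido for 1H-pyrazol-4-yl on this aromatic carbon gives a 5.0-fold lower number from compound 1 to compound 3 (0.70 log units; beyond the scatter) and shows that the methanesulfonamido group is not needed for agonist activity at this place, since an aromatic ring can stand there and the number still falls. The earlier step, a 2.1-fold lower number from compound 1 to compound 2 (0.33 log units; beyond the scatter), kept the methanesulfonamido group and so could not show this. Nothing measured here accounts for the size or direction of the new step.

As far as these compounds go, whether an amine, a carboxylic acid or a 1H-imidazol-4-yl ring on the same aromatic carbon would give a lower or a higher number stays open. From the compounds shown here alone, it also stays open whether the methyl on the aromatic carbon of compound 2 would lower the number further when combined with 1H-pyrazol-4-yl.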